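The compounds below may be only part of what the source reports. "The series", "measured", "known", "first", "only" and "open" are said of these compounds alone.

Compound 1 `CC(=O)OCc1ccc2oc(=O)c(C(=O)Oc3cccc(Cl)c3)cc2c1`: 49.1%
Compound 2 `CC(=O)OCc1ccc2oc(=O)c(C(=O)Oc3cccc(Br)c3)cc2c1`: 21.8%

In a functional assay on HT-1080 cells (Homo sapiens), read by transwell migration, with a stated time of 24 h, tested at 1 uM (a lower number here means a stronger effect, a higher number a weaker effect of the compound at the concentration tested), compound 2 gives the lowest of the two numbers, and a number 27.3 percentage points lower from compound 1 to compound 2 (beyond the scatter). Compound 3 `CC(=O)OCc1ccc2oc(=O)c(C(=O)Sc3ccccc3)cc2c1` differs from compound 2 as follows: phenylsulfanyl in place of 3-bromophenoxy on a carbonyl carbon. For the measured compounds named here, no measured step touches this part of the molecule; the only measured step swaps bromo for chloro on an aromatic carbon, so it offers no direct guide. Without such a guide, the expected step of a number 13.2 percentage points higher from compound 2 to compound 3 (beyond the scatter) is set at a modest size with a wide range. Compound 3 is therefore estimated at 35%, between 12% and 62%.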

Compound 3, a percentage reported as activity, at one concentration (the size of the read-out at that concentration, not a potency): 83.5%
For compound 3 the middle estimate is 48.5 percentage points below the measured one; measured number outside the range, above it.
By their numbers in this assay, from the lowest: compound 2; then compound 1; then compound 3.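

Replacing 3-bromophenoxy with phenylsulfanyl on the carbonyl carbon in this assay gives a number 61.7 percentage points higher from compound 2 to compound 3 (beyond the scatter) and replacing 3-chlorophenoxy with it gives a number 34.4 percentage points higher from compound 1 to compound 3 (beyond the scatter). Both steps are large, while the swap of bromo for chloro was modest, so this position tolerates some changes far less well than the halogen pair alone could show. No measurement available here explains the change.

Phenylsulfanyl differs from both earlier groups in its sulfur and in lacking a halogen, and these two differences remain unseparated. An unsubstituted phenoxy group or a 3-bromophenylsulfanyl group would pull them apart.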